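A few compounds are considered here, and "the series" means these few. Any claim that something is new, unique, unknown or untested is made for them only; others in the source may bear on it.

Three compounds have been measured so far:

Compound 1, `CC1(C)Oc2ccc(C#N)cc2[C@@H](/N=C(\NC#N)Nc2ccccc2)[C@@H]1O`: 1400 nM
Compound 2, `CC1(C)Oc2ccc(C#N)cc2[C@@H](NC(=O)Nc2ccccc2)[C@@H]1O`: 800 nM
Compound 3, `CC(=O)O[C@H]1[C@H](/N=C(\NC#N)Nc2ccccc2)c2cc(C#N)ccc2OC1(C)C`: 2600 nM

All three were tested in a functional assay (aorta) for inhibition, with Rattus norvegicus as the target; on this read-out lower numbers stand for stronger inhibition and higher numbers for weaker inhibition. Compound 2 stands at the low end of the three numbers; its nearest neighbour is compound 1, and the two lie within the scatter of each other, whereas compound 3 lies beyond the scatter from compound 2. How compound 1 and compound 2 differ in their cores is not broken down here.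

Compound 3 carries one change relative to compound 1, (acetyl in place of hydrogen on an oxygen on a saturated carbon), and in this assay that change gave a 1.9-fold higher number from compound 1 to compound 3 (0.27 log units; within the scatter).

The unmeasured compound 4, `CC(=O)O[C@H]1[C@H](NC(=O)Nc2ccccc2)c2cc(C#N)ccc2OC1(C)C`, bears the same kind of change relative to compound 2: acetyl in place of hydrogen on an oxygen on a saturated carbon. The two place descriptions agree word for word, so the surroundings of the change are the same in both pairs.

Because compound 1 moved to compound 3 by a 1.9-fold higher number from compound 1 to compound 3 (0.27 log units; within the scatter), compound 4 is expected to sit somewhat higher than compound 2 in this assay, by a step of about a 1.9-fold higher number from compound 2 to compound 4 (0.27 log units; within the scatter), which would again fall within the scatter. The estimate for compound 4 in this assay is therefore 1500 nM, with a likely range from 700 nM to 3500 nM.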

Compound 4, half-maximal inhibitory concentration: 4400 nM
The estimate for compound 4 lay 2.9-fold (0.47 log units) below the measured number; the measured number lies above the stated range.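

In this assay, the change from hydroxy to acetoxy gave a 5.5-fold higher number from compound 2 to compound 4 (0.74 log units; beyond the scatter), so the size of the step seen on the core of compound 1 did not carry over to the core of compound 2. Set side by side, the two steps differ by more than the scatter allows, and the shared description of the change therefore did not settle its size in this series: the same change on two cores in this assay, a 1.9-fold higher number (0.27 log units; within the scatter) from compound 1 to compound 3 and a 5.5-fold higher number (0.74 log units; beyond the scatter) from compound 2 to compound 4, 3.0-fold (0.47 log units) apart, beyond the scatter of two such steps This comparison rests on only one pair for each core, and it shows neither what in the two cores separates the steps nor how the same change would read on a further core.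

The compounds shown have only hydrogen or acetyl on this oxygen, so it remains open whether a longer ester such as propionyl or benzoyl, or a methyl ether, would also give steps that differ between the two cores. As far as these compounds go, it is equally open how either core would read with an amine or a fluorine in place of the hydroxy group, and whether such a replacement would give steps that agree more closely than these two do.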